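The source may report more compounds than this note shows. Statements on the series, on what has been measured and on what is new or still open speak of the compounds shown alone.

Going by the values given here, in a functional assay on SiHa cells (Homo sapiens) for inhibition, read by CCK-8 assay, with a stated time of 72 h, tested at 1 uM (on this read-out lower numbers stand for less inhibition of growth and higher numbers for more inhibition of growth at the one concentration tested), compound 1 `CN(C)C(=O)c1cc2cnc(Nc3ccc(NC(=O)C4(C(=O)Nc5ccc(F)cc5)CC4)cc3)nc2n1C1CCCC1` gives 36.5%, the highest of the three numbers so far. Compound 2 `CN(C)C(=O)c1cc2cnc(Nc3ccc(NC(=O)C4(C(=O)Nc5ccc(Cl)cc5)CC4)cc3)nc2n1C1CCCC1` gives -0.8% and compound 3 `CN(C)C(=O)c1cc2cnc(Nc3ccc(NC(=O)C4(C(=O)Nc5cccc(O)c5)CC4)cc3)nc2n1C1CCCC1` gives -19.8%. The next structure, compound 4 `CN(C)C(=O)c1cc2cnc(Nc3ccc(NC(=O)C4(C(=O)Nc5ccc(Br)cc5)CC4)cc3)nc2n1C1CCCC1`, keeps everything in compound 1 except one atom: bromo in place of fluoro on an aromatic carbon. Bromo thus takes the place of fluoro on an aromatic carbon, para to a large group. Among the compounds with values here, the closest precedent is chloro in place of fluoro, a large change, with a number 37.3 percentage points lower from compound 1 to compound 2 (beyond the scatter). Replacing the whole 4-fluorophenyl with 3-hydroxyphenyl bears on it less directly, but it also moved the number down, with a number 56.3 percentage points lower from compound 1 to compound 3 (beyond the scatter). Within the data shown here, no bromo compound has been measured yet, so the chloro step is only a guide, and a single precedent leaves the size uncertain. A large downward step resembling it is expected, namely a number 34.5 percentage points lower from compound 1 to compound 4 (beyond the scatter). Compound 4 is therefore estimated at 2%, with an expected range from -25% to 30%.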

Compound 4, percent growth inhibition at one concentration: 23.2%
Beside the measured number, compound 4's estimate is 21.2 percentage points below it, within the range that was stated.
By their numbers in this assay, from the lowest: compound 3; then compound 2; then compound 4; then compound 1.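

In this assay, bromo in place of fluoro at this position, para to a large group, gives a number 13.3 percentage points lower from compound 1 to compound 4 (beyond the scatter), so swapping the fluoro for a different halogen need not cost as much as the chloro precedent did. Bromo in place of chloro gives a number 24 percentage points higher from compound 2 to compound 4 (beyond the scatter), which means the numbers do not fall steadily from fluoro through chloro to bromo, with compound 2 going against any such trend. Compound 4 also differs clearly from the 3-hydroxyphenyl compound, with a number 43 percentage points higher from compound 3 to compound 4 (beyond the scatter), but nothing available explains these steps.

From the compounds shown here alone, whether an iodo, methyl or methoxy group at the same position would lie nearer compound 1 or compound 2 remains open. So does whether an amine there would keep any of the growth inhibition seen with fluoro and bromo.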